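The compounds below may be only part of what the source reports. "The series", "measured", "known", "first", "only" and "open" are said of these compounds alone.

Compound 2 `COc1cc2[nH]ncc2cc1-c1ccccc1C(F)(F)F` has been tested in an assay on CHO-K1 cells for antagonist activity at transient receptor potential cation channel subfamily V member 3 (Homo sapiens), read by FLIPR and calcium flux, with a stated time of 10 min; a lower number here means a stronger inhibitor, a higher number a weaker inhibitor. In this assay compound 2 gives > 30000 nM, which is a limit of the assay and not a number. Its closest measured relative is compound 1 `FC(F)(F)c1ccccc1-c1ccc2[nH]ncc2c1`, which carries hydrogen where compound 2 carries methoxy. In this assay compound 1 gives > 30000 nM, again a limit of the assay. The step that the two limits leave unreadable from compound 1 to compound 2 therefore cannot be read in size, as both values sit at the limit of > 30000 nM in this assay, at which 2 of the 2 values shown sit. Compound 3 `FC(F)(F)Oc1cc2[nH]ncc2cc1-c1ccccc1C(F)(F)F` has not yet been measured. It differs from compound 2 by trifluoromethyl in place of methyl on an oxygen on an aromatic ring. Among the measured compounds shown here, no measured step covers this change, and the one measured step, from compound 1 to compound 2, has no readable size, so it offers no guide to direction or magnitude. The step of a number no higher from compound 2 to compound 3 (the limit leaves the size open) is therefore expected, with little confidence, to leave the value at the limit once more. Compound 3 is estimated at 30000 nM in this assay, with a range from 10000 nM to 100000 nM.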

Compound 3, half-maximal inhibitory concentration: > 30000 nM
Compound 3 gave a limit, no number (the forecaster's own chance of this, stated with the estimate: 80%); the middle value sits exactly at the limit.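

In this assay compound 3 gives > 30000 nM, a limit of the assay and not a number. The steps among compound 1, compound 2 and compound 3 therefore cannot be read in size: the limit of > 30000 nM in this assay, at which 3 of the 3 values shown sit. The compounds shown leave open how strongly any of the three inhibits, and whether hydrogen, methoxy or trifluoromethoxy makes any difference to that.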